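The source may report more compounds than this note shows. Statements on the series, on what has been measured and on what is new or still open speak of the compounds shown alone.

In a functional assay on MCF7 cells (Homo sapiens) for antiproliferative activity, read by MTT assay, with a stated time of 72 h (on this read-out lower numbers stand for stronger inhibition and higher numbers for weaker inhibition), compound 1 (`Cc1cc(NCCN(C)C)nc2ccc(NC(=O)c3ccc(Cl)c(Cl)c3)cc12`) gives 2550 nM. Compound 2 (`CCN(CC)c1cc(C)c2cc(NC(=O)c3ccc(Cl)c(Cl)c3)ccc2n1`) gives > 50000 nM, which is a limit and not a number, and it stands at the limit of > 50000 nM in this assay, at which 1 of the 2 values shown sits. For the measured compounds named here, the only measured step is large: an at least 19-fold higher number from compound 1 to compound 2 (1.29 log units; beyond the scatter), with diethylamino in place of (2-(dimethylamino)ethyl)amino. Compound 3 (`Cc1cc(N2CCCCC2)nc2ccc(NC(=O)c3ccc(Cl)c(Cl)c3)cc12`) keeps the shared core and has piperidin-1-yl in place of diethylamino on an aromatic carbon. Like compound 2, compound 3 lacks the (2-(dimethylamino)ethyl)amino group of compound 1, so that large step bears on it only indirectly, and no change beyond the scatter is expected in this assay. The expected step is a number no higher from compound 2 to compound 3 (the limit leaves the size open). For compound 3 the estimate is 50000 nM, with an expected range of 15000 nM to 100000 nM.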

Compound 3, half-maximal inhibitory concentration: 31100 nM
Estimate against measurement, compound 3: 1.6-fold (0.21 log units) above, and the stated range covers the measured number.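

In this assay, piperidin-1-yl gives a measured number for a group without the (2-(dimethylamino)ethyl)amino chain, and the large loss at this position holds: a 12-fold higher number from compound 1 to compound 3 (1.09 log units; beyond the scatter). Replacing diethylamino with the ring gives an at least 1.6-fold lower number from compound 2 to compound 3 (0.20 log units; that floor lies within the scatter), a floor that shows no change beyond the scatter. The true size of that step stays open because compound 2 is a limit and not a number: the limit of > 50000 nM in this assay, at which 1 of the 3 values shown sits.

Still open, from the compounds shown here alone, is whether a longer chain such as (3-(dimethylamino)propyl)amino, or a piperazin-1-yl ring, would match compound 1 at this position.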